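Dihalophenyl to methylphenyl on the triazole nitrogen

A few compounds are considered here, and "the series" means these few. Any claim that something is new, unique, unknown or untested is made for them only; others in the source may bear on it.

Compound 1 `CCOC(=O)C1=Cc2ccccc2OC1(OCc1cn(-c2ccc(F)cc2)nn1)C(F)(F)F` — 9100 nM
Compound 2 `CCOC(=O)C1=Cc2ccccc2OC1(OCc1cn(-c2ccc(F)c(Cl)c2)nn1)C(F)(F)F` — 25300 nM

In a functional assay on MCF7 cells (Homo sapiens) for inhibition, read by MTT assay, with a stated time of 24 h (a lower number here means a stronger inhibitor, a higher number a weaker inhibitor), compound 2 gives 25300 nM, the highest number of the two shown, and compound 1 gives 9100 nM. For the measured compounds named here, the only measured step, a 2.8-fold higher number from compound 1 to compound 2 (0.44 log units; beyond the scatter), came with chloro in place of hydrogen. Compound 3 `CCOC(=O)C1=Cc2ccccc2OC1(OCc1cn(-c2ccc(C)cc2)nn1)C(F)(F)F` carries 4-methylphenyl in place of 3-chloro-4-fluorophenyl on an aromatic nitrogen. Going by the values given here, that change removes the chloro, while the fluorine-to-methyl swap is covered by no measured pair. Compound 3 is expected to show a 2.7-fold lower number from compound 2 to compound 3 (0.43 log units; beyond the scatter), because a 2.8-fold higher number from compound 1 to compound 2 (0.44 log units; beyond the scatter) was the change it undoes. Compound 3 is estimated at 9500 nM, range 3500 nM to 26000 nM.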

Compound 3, half-maximal inhibitory concentration: 26700 nM
Compound 3: the middle estimate sits 2.8-fold (0.45 log units) below what was measured; the whole stated range lies below it.
By their numbers in this assay, from the lowest: compound 1; then compounds 2 and 3 (each within the scatter of the next).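

In this assay, 4-methylphenyl in place of 3-chloro-4-fluorophenyl on the aromatic nitrogen gave a 1.1-fold higher number from compound 2 to compound 3 (0.02 log units; within the scatter), so these two groups cannot be told apart here. Methyl in place of fluoro on the aromatic carbon gave a 2.9-fold higher number from compound 1 to compound 3 (0.47 log units; beyond the scatter), which shows that a change without any chloro also separates a compound from compound 1. Among these three compounds, the 4-fluorophenyl of compound 1 alone gives the lower number. No measurement available here explains these differences. As far as these compounds go, how a methoxy group or an amine on that aromatic ring would read remains open.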